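Thiophen-3-yl in place of phenyl: small step expected

The compounds below may be only part of what the source reports. "The series", "measured", "known", "first", "only" and "open" are said of these compounds alone.

Compound 2 `CC1=C(C(=O)OC(C)C)C(c2ccccc2)N/C(=N/C#N)N1` stands second highest of the three numbers in an assay on HeLa cells for displacement of a labelled ligand from adenosine receptor A3 (Homo sapiens), with a stated time of 180 min, tested at 1 uM; on this read-out lower numbers stand for less inhibition and higher numbers for more inhibition at the one concentration tested (going by the name of the read-out): compound 2 gives 6%. Compound 1 `CC1=C(C(=O)OC(C)C)[C@H](c2ccco2)N/C(=N/C#N)N1` gives 1%, within the scatter of compound 2. Compound 3 `CCOC(=O)C1=C(C)NC(=O)NC1C1CCCC1` gives 18%, beyond the scatter above compound 2. Among the measured compounds shown here, no step between compounds that differ in one place has been measured, so the size of a single change is not known from these data. Compound 4 `CC1=C(C(=O)OC(C)C)C(c2ccsc2)N/C(=N/C#N)N1` differs from compound 2 by thiophen-3-yl in place of phenyl on a saturated ring carbon. All three measured numbers are low on this read-out, and nothing in them points to a large step for this change; a step no larger than the scatter is expected, in either direction. Compound 4 is estimated at 6%, with a range from 0% to 20%, which means an expected step of no change at the digits printed from compound 2 to compound 4 (within the scatter).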

Compound 4, a percentage reported as inhibition, at one concentration (the size of the read-out at that concentration, not a potency): 13%
For compound 4 the middle estimate is 7 percentage points below the measured one; the range from low to high includes it.
By their numbers in this assay, from the lowest: compounds 1, 2, 4 and 3 (each within the scatter of the next, the first and the last beyond it).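

In this assay this saturated ring carbon now has its first single-change step: thiophen-3-yl in place of phenyl gives a number 7 percentage points higher from compound 2 to compound 4 (within the scatter) on the shared core. This one step does not separate the two aromatic groups, and both compounds stay low on this read-out. Nothing at hand bears on the reason for the size of this step. Still open, as far as these compounds go, is whether an amine or a carboxylic acid on this carbon would give a step beyond the scatter. Also open, from the compounds shown here alone, is how a longer chain in place of the isopropoxycarbonyl group would read.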